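The source may hold more compounds than are shown below. What is called first, only, known or untested is meant among the compounds shown, and "the series" means these compounds.

Working notes on the series, all read in a functional assay on HeLa cells (Homo sapiens) for inhibition, read by MTT assay, with a stated time of 72 h; on this read-out higher numbers stand for weaker inhibition and lower numbers for stronger inhibition. Compound 1 (`O=C(Nc1ccc(Br)cc1)Nc1ccc(Nc2ncnc3[nH]ncc23)cc1`) gives > 10000 nM, which is a limit and not a number. Compound 2 (`O=C(Nc1ccc(Nc2ncnc3[nH]ncc23)cc1)Nc1ccc(C(F)(F)F)cc1`) gives > 10000 nM, again a limit. Compound 3 (`O=C(Nc1ccc(Oc2ncnc3[nH]ncc23)cc1)c1ccc(Br)cc1`) gives > 10000 nM, also a limit. The numbers shown therefore place compound 3 only at the limit of > 10000 nM in this assay, at which 3 of the 3 values shown sit, and no order can be drawn within the set.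

The next structure is compound 4 (`O=C(Nc1ccc(Oc2ncnc3[nH]ncc23)cc1)Nc1cccc(F)c1`). The change is (3-fluorophenyl)amino in place of 4-bromophenyl on a carbonyl carbon.

For the measured compounds named here, the one measured step with any bearing is a step that the two limits leave unreadable from compound 1 to compound 2. Going by the values given here, it gives no size to carry over to the new change, and no measured step has a readable size. No step beyond the scatter is therefore expected in this assay, and no direction is favoured. Compound 4 is expected to stay close to the limit, quite possibly reported only as a limit itself.

The estimated step is a step that the limit leaves unreadable from compound 3 to compound 4. The estimated value for compound 4 is 14000 nM, with an expected range of 4000 nM to 40000 nM.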

Compound 4, half-maximal inhibitory concentration: > 10000 nM
Compound 4 was reported as a limit; the forecaster's own chance of this, stated with the estimate: 70%; the middle value does not contradict the limit.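

In this assay, compound 3 and compound 4 are both reported only as limits, so no size can be read for the change between them. The compounds shown leave open what any of them would actually measure in this assay, and whether any change among them shifts the value at all: the limit of > 10000 nM in this assay, at which 4 of the 4 values shown sit.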